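The source may hold more compounds than are shown below. What is called first, only, known or untested is meant among the compounds shown, and "the series" means these compounds.

Values measured in a functional assay on NCI-H322 cells (Homo sapiens) for antiproliferative activity; on this read-out higher numbers stand for weaker inhibition of growth and lower numbers for stronger inhibition of growth:

- Compound 1 `CCCCCCCCC(O)CCCCCC/C=C1\CC(CO)(COC(=O)C(C)(C)C)OC1=O`: > 10 ug/mL
- Compound 2 `CC(C)(C)C(=O)OCC1(CO)C/C(=C\CCCCCCCCCCCO)C(=O)O1`: > 10 ug/mL
- Compound 3 `CC(C)(C)C(=O)OCC1(CO)C/C(=C/CCCCCCCCCCCCCCC=O)C(=O)O1`: > 10 ug/mL

Compound 2 stands at > 10 ug/mL, which is a limit and not a number. Among the compounds with values here, the other two values are limits as well, so the series so far offers the limit of > 10 ug/mL in this assay, at which 3 of the 3 values shown sit, and no measured number.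

Compound 4 `CC(=O)NCCCCCCCCCCCCCCC/C=C1\CC(CO)(COC(=O)C(C)(C)C)OC1=O` is the next to be read against compound 2. The change is 4-acetamidobutyl in place of hydroxy on a saturated chain carbon, ten or more bonds along the chain from a double-bonded chain carbon.

Within the data shown here, the one measured step that bears on this is a step that the two limits leave unreadable from compound 1 to compound 2, so no size or direction can be carried over from it. No step beyond the scatter is therefore expected, and the result will most likely be another limit. The expected step is a step that the limit leaves unreadable from compound 2 to compound 4, an estimate with little behind it. For compound 4 the estimated value is 12 ug/mL, with an expected range of 5 ug/mL to 30 ug/mL.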

Compound 4, concentration for 50% growth inhibition: > 10 ug/mL
Compound 4 gave a limit, no number; the forecaster's own chance of this, stated with the estimate: 75%; the middle value is on the limit's open side.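

Within the data shown here, compound 4 gives > 10 ug/mL in this assay, a limit and not a number, so no step from compound 2 to compound 4 can be read. The compounds shown leave open whether any change to the chain yields a measurable value, with the series still at one ceiling: the limit of > 10 ug/mL in this assay, at which 4 of the 4 values shown sit.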